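A few compounds are considered here, and "the series" means these few. Any claim that something is new, unique, unknown or untested is made for them only; others in the source may bear on it.

Compound 1 `COc1ccc2occ(CSC(=S)N3CCCC3)c(=O)c2c1`: 3100 nM in a functional assay on HEp-2 cells (Homo sapiens) for antiproliferative activity, read by MTT assay, with a stated time of 72 h; a higher number here means a weaker inhibitor, a lower number a stronger inhibitor
Compound 2 `COc1ccc2occ(CSC(=S)N3CCOCC3)c(=O)c2c1`: 4800 nM in this assay

Within the data shown here, compound 2 holds the highest of the two numbers measured so far in this assay, but its only neighbour is close: the step of a 1.5-fold higher number from compound 1 to compound 2 (0.19 log units; within the scatter) lies within the scatter, so the two compounds cannot be told apart on these data. Compound 3 `O=c1c(CSC(=S)N2CCOCC2)coc2ccccc12` has not yet been measured. It differs from compound 2 in one place: hydrogen in place of methoxy on an aromatic carbon. Among the measured compounds shown here, the single measured step exchanges one ring for another on a thiocarbonyl carbon and leaves the methoxy untouched, so no measured pair bears on the present change. With nothing to lean on, the step expected here, a 1.1-fold higher number from compound 2 to compound 3 (0.06 log units; within the scatter), is small, in no clear direction, and need not rise above the scatter. Compound 3 is therefore expected to give about 5500 nM in this assay, with a plausible range from 2000 nM to 15000 nM.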

Compound 3, half-maximal inhibitory concentration: 4400 nM
Estimate against measurement, compound 3: 1.3-fold (0.10 log units) above; the measured number falls inside the stated range.
By their numbers in this assay, from the lowest: compounds 1, 3 and 2 (each within the scatter of the next).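

Among these compounds, replacing the methoxy with hydrogen on this aromatic carbon gives a 1.1-fold lower number from compound 2 to compound 3 (0.04 log units; within the scatter) in this assay, the first measured look at this position. Within what this assay can resolve, the morpholin-4-yl compounds keep their activity without the methoxy, so hydrogen serves as well as this group here. No measurement at hand explains why the number holds.

Hydrogen and methoxy are the only groups compared at this place, so it remains open whether a chlorine atom, an amine or a carboxylic acid there would shift the number beyond the scatter. As far as these compounds go, it is also open whether the methoxy can be dropped with equally little effect when pyrrolidin-1-yl takes the place of morpholin-4-yl on the thiocarbonyl carbon.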